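A few compounds are considered here, and "the series" means these few. Any claim that something is new, unique, unknown or untested is made for them only; others in the source may bear on it.

Of the compounds shown here, two from this series have been measured in an assay on membranes from brain for displacement of a labelled ligand from Sigma non-opioid intracellular receptor 1 (Cavia porcellus), read by scintillation counting, with a stated time of 120 min; on this read-out higher numbers stand for weaker inhibition and lower numbers for stronger inhibition. Compound 1, `COC1Cc2c(csc2-c2ccccc2)C2(CCN(Cc3ccccc3)CC2)O1`, gives 1 nM in this assay. For the measured compounds named here, compound 2, `COC1Cc2c(csc2-c2ccc(C#N)cc2)C2(CCN(Cc3ccccc3)CC2)O1`, gives 0.25 nM in this assay, which is the lower of the two numbers; the only measured step that leads to it is a 4.0-fold lower number from compound 1 to compound 2 (0.60 log units; beyond the scatter), so compound 2 stands apart from compound 1 by more than the usual scatter.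

Compound 3, `COC1Cc2c(csc2-c2cccnc2)C2(CCN(Cc3ccccc3)CC2)O1`, has not yet been measured. Its structure differs from compound 2 in one place: pyridin-3-yl in place of 4-cyanophenyl on an aromatic carbon. Going by the values given here, only one measured step bears on this change, namely a 4.0-fold lower number from compound 1 to compound 2 (0.60 log units; beyond the scatter), and it concerns the cyano group that compound 3 no longer carries. Among the compounds with values here, no measured compound shows what a pyridin-3-yl group does on this part of the shared core, so that half of the change rests on no evidence at all. The step from compound 2 to compound 3 is therefore expected to undo, roughly, the gain that came with the cyano group: a 4.0-fold higher number from compound 2 to compound 3 (0.60 log units; beyond the scatter) is the estimated size. On that basis compound 3 is expected to give about 1 nM in this assay, most likely between 0.3 nM and 4 nM.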

Compound 3, inhibition constant: 2.2 nM
Estimate against measurement, compound 3: 2.2-fold (0.34 log units) below, within the range that was stated.
By their numbers in this assay, from the lowest: compound 2; then compound 1; then compound 3.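

In this assay, for the compounds shown here, the earlier compounds showed only what a nitrile on the phenyl ring does, whereas compound 3 changes the aromatic ring itself at this place, on the carbon next to the ring sulfur. Swapping phenyl for pyridin-3-yl gives a 2.2-fold higher number from compound 1 to compound 3 (0.34 log units; beyond the scatter), a modest step in the opposite direction to the one seen with the nitrile, and swapping 4-cyanophenyl for pyridin-3-yl gives an 8.8-fold higher number from compound 2 to compound 3 (0.94 log units; beyond the scatter), the largest step among these three compounds, so this position responds to both kinds of change while compound 3 still gives 2.2 nM. Nothing measured here explains why the numbers move this way.

The compounds shown leave open whether the result belongs to pyridin-3-yl alone or would also hold for pyridin-2-yl or pyridin-4-yl, which carry the ring nitrogen elsewhere. They also leave open whether a nitrile added to the pyridine ring would lower the number as it does on phenyl, and whether other groups on the phenyl ring, such as an amine or a carboxylic acid, would move it in either direction.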